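The source may report more compounds than this note shows. Statements on the series, on what has been measured and on what is new or still open speak of the compounds shown alone.

Going by the values given here, compound 3 `NC(=O)c1c(NC(=O)c2cccc([N+](=O)[O-])c2)sc2c1CCN(C(=S)Nc1ccccc1Cl)C2` gives the lowest of the three numbers so far in a functional assay on MKN-74 cells (Homo sapiens) for antiproliferative activity, with a stated time of 24 h (on this read-out lower numbers stand for stronger inhibition and higher numbers for weaker inhibition), at 8850 nM. Compound 1 `NC(=O)c1c(NC(=O)c2ccccc2)sc2c1CCN(C(=S)Nc1ccccc1Cl)C2` gives 11800 nM in this assay, and compound 2 `NC(=O)c1c(NC(=O)c2ccccc2F)sc2c1CCN(C(=S)Nc1ccccc1Cl)C2` gives 11100 nM. The three sit close together: the change from compound 1 to compound 2 amounts to a 1.1-fold lower number from compound 1 to compound 2 (0.03 log units; within the scatter), from compound 1 to compound 3 to a 1.3-fold lower number from compound 1 to compound 3 (0.12 log units; within the scatter), and from compound 2 to compound 3 to a 1.3-fold lower number from compound 2 to compound 3 (0.10 log units; within the scatter), so none of these steps reaches beyond the scatter.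

Compound 4 `NC(=O)c1c(NC(=O)c2ccncn2)sc2c1CCN(C(=S)Nc1ccccc1Cl)C2` differs from compound 3 by pyrimidin-4-yl in place of 3-nitrophenyl on a carbonyl carbon. The three measured steps all concern the same carbonyl-bound aryl group, and each of them stayed within the scatter, so the data give no sign that this part of the molecule moves the read-out in this assay. For compound 4 an estimated step of a 1.2-fold higher number from compound 3 to compound 4 (0.09 log units; within the scatter) is therefore expected, which is no step beyond the scatter. Compound 4 is thus expected to give about 11000 nM in this assay, within a range from 5000 nM to 25000 nM.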

Compound 4, half-maximal inhibitory concentration: 28400 nM
The estimate for compound 4 lay 2.6-fold (0.41 log units) below the measured number; measured number above the stated range.
By their numbers in this assay, from the lowest: compounds 3, 2 and 1 (each within the scatter of the next); then compound 4.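

Across the phenyl, 2-fluorophenyl and 3-nitrophenyl groups, the aryl group on this carbonyl carbon had seemed to make no difference in this assay, but the position does respond once a carbon-only aromatic ring gives way to pyrimidin-4-yl. The inhibition weakens against all three earlier compounds, with (a 3.2-fold higher number from compound 3 to compound 4 (0.51 log units; beyond the scatter)), (a 2.6-fold higher number from compound 2 to compound 4 (0.41 log units; beyond the scatter)) and (a 2.4-fold higher number from compound 1 to compound 4 (0.38 log units; beyond the scatter)), each step modest but beyond the scatter. Nothing available here explains why this replacement weakens the inhibition.

The compounds shown leave open whether this loss is particular to pyrimidin-4-yl or would also appear with a pyridinyl group, which has a single ring nitrogen. They also leave open how a phenyl bearing an amine or a carboxylic acid would behave at this carbonyl carbon.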